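The compounds below may be only part of what the source reports. "The series", "measured", "known", "first", "only" and "open" are said of these compounds alone.

Measured so far, in a physicochemical assay for solubility, at pH 6.5; on this read-out higher numbers stand for higher solubility and lower numbers for lower solubility:

- compound 1 `Cn1ncc2c(NCc3ccc(Cl)cc3)nc(Cl)nc21`: 145000 nM
- compound 2 `CNc1nc(Cl)nc2c1cnn2C`: 206000 nM
- compound 3 `FC(F)(F)c1ccc(C2(Nc3nc(Cl)nc4[nH]ncc34)CC2)cc1`: 105000 nM

Compound 1 stands second highest of the three numbers, but its gap to compound 2 above it and to compound 3 below it each lie within the usual scatter, so the three values cannot be ordered with confidence.

Compound 4 `Cn1ncc2c(NCc3ccc(C(F)(F)F)cc3)nc(Cl)nc21` is next for this assay. It differs from compound 1 in one place: trifluoromethyl in place of chloro on an aromatic carbon. Going by the values given here, no pair of measured compounds shows this change on its own, so no direct step can be read off. Compound 3, which also carries a trifluoromethyl, gives 105000 nM, a value close to that of compound 1.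

For compound 4 the expected step is a 1.3-fold lower number from compound 1 to compound 4 (0.12 log units; within the scatter), small and not clearly beyond the scatter. Compound 4 is therefore estimated at 110000 nM, with a range from 50000 nM to 240000 nM.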

Compound 4, solubility: 164000 nM
Compound 4: middle estimate off by 1.5-fold (0.17 log units), on the low side, within the range that was stated.
By their numbers in this assay, from the lowest: compounds 3, 1, 4 and 2 (each within the scatter of the next).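

In this assay the step is a 1.1-fold higher number from compound 1 to compound 4 (0.05 log units; within the scatter) for trifluoromethyl in place of chloro, on an aromatic carbon para to a large group. Going by these compounds alone, this is the first direct reading of this change: at this place, 4 heavy atoms entering for 1 leave the read-out within the scatter. Nothing available bears on why the two groups read alike.

Still open, as far as these compounds go, is whether an amine or a carboxylic acid at this place would also stay within the scatter. Also open, from the compounds shown here alone, is whether the same change reads alike on a different core.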